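Side-chain swaps on the shared core: cytotoxicity notes

This account rests on a few compounds, and the source may have more. Where it says the series, first, only, none or still open, it means among the compounds named here.

Compound 1, `O=C1O[C@@H](CN2CCC(O)CC2)CN1c1ccc(-n2cc(-c3ccccn3)cn2)c(F)c1`: in an ADME assay on HEK293-A cells (Homo sapiens) for cytotoxicity, read by MTT assay, with a stated time of 48 h (on this read-out lower numbers stand for stronger inhibition and higher numbers for weaker inhibition), compound 1 gives > 400 ug/mL, which is a limit of the assay.
Compound 2, `O=C1O[C@@H](Cn2ccnc2)CN1c1ccc(-n2cc(-c3ccccn3)cn2)c(F)c1`: in this assay compound 2 gives > 400 ug/mL, which is also a limit of the assay.

Compound 2 therefore stands at the limit of this assay and not at a number; both values shown sit there, as the limit of > 400 ug/mL in this assay, at which 2 of the 2 values shown sit, records. The step that the two limits leave unreadable from compound 1 to compound 2 cannot be read from two limits, so the exchange of 1H-imidazol-1-yl for 4-hydroxypiperidin-1-yl on a saturated chain carbon bound to a saturated ring carbon gave no measurable size.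

Compound 3, `CN(C)S(=O)(=O)NC[C@H]1CN(c2ccc(-n3cc(-c4ccccn4)cn3)c(F)c2)C(=O)O1`, is the next case on the same position: (dimethylsulfamoyl)amino in place of 1H-imidazol-1-yl on a saturated chain carbon bound to a saturated ring carbon. Going by the values given here, the single measured step bears on it only in that two different groups on this saturated chain carbon bound to a saturated ring carbon both left the read-out at the limit; its size is not readable, so no step beyond the scatter is expected in this assay. The expected step is a number no higher from compound 2 to compound 3 (the limit leaves the size open), within the scatter. Compound 3 is expected to give 400 ug/mL in this assay, with a range from 200 ug/mL to 800 ug/mL, and most likely again only a limit.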

Compound 3, half-maximal inhibitory concentration: 249 ug/mL
Compound 3: the middle estimate sits 1.6-fold (0.21 log units) above what was measured, and the stated range covers the measured number.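

In this assay compound 3 gives 249 ug/mL, a plain number, the first such number shown on this saturated chain carbon bound to a saturated ring carbon. So the read-out at this place can leave the limit when the group there is (dimethylsulfamoyl)amino. Against the earlier compounds the change reads as an at least 1.6-fold lower number from compound 2 to compound 3 (0.20 log units; that floor lies within the scatter) and as an at least 1.6-fold lower number from compound 1 to compound 3 (0.20 log units; that floor lies within the scatter) with the true size open in both, so neither step is shown to go beyond the scatter. The limit still holds most of what is shown for this position: the limit of > 400 ug/mL in this assay, at which 2 of the 3 values shown sit.

Open, on these data alone, is whether the number belongs to the (dimethylsulfamoyl)amino group as a whole or to one part of it, and a primary amine or a methanesulfonylamino group on the same saturated chain carbon bound to a saturated ring carbon would bear on that. Also open, as far as these compounds go, is the true size of both steps, with compound 1 and compound 2 known only as limits.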